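The source may report more compounds than this note shows. Statements on the series, on what has been measured and on what is new or still open speak of the compounds shown alone.

Measured so far:
- compound 1 `C#CC[C@@H]1C[C@H](n2cccc2C(C)=O)C(=O)O1` — 8.03%
- compound 2 `C#CC[C@@H]1C[C@H](n2cccc2)C(=O)O1` — 6.56%
- compound 3 `C#CC[C@H]1C[C@H](n2cccc2)C(=O)O1` — 12.2%

In a functional assay on N2a cells (Mus musculus), with a stated time of 48 h, tested at 0.01 uM (a higher number here means a stronger effect of the compound at the concentration tested, a lower number a weaker effect), the three numbers all lie within the usual scatter of one another, so compound 3 does not stand apart from compound 1 or compound 2, even though its figure is the one the others are measured against here. The step of a number 5.6 percentage points higher from compound 2 to compound 3 (within the scatter) is within the scatter, which fits (the fact that compounds 2 and 3 differ only in the configuration as drawn). The step of a number 1.5 percentage points lower from compound 1 to compound 2 (within the scatter) is also within the scatter and is the one that bears on the next change: compound 4 `C#CC[C@H]1C[C@H](n2cccc2C(=O)C(F)(F)F)C(=O)O1` differs from compound 3 by (trifluoromethyl)carbonyl in place of hydrogen on an aromatic carbon. Within the data shown here, that is the reverse of removing an acetyl, with a different carbonyl group entering, so the one comparable measured step points to no change beyond the scatter. The step of a number 2.2 percentage points lower from compound 3 to compound 4 (within the scatter) is therefore expected to be small, and compound 4 is estimated at 10%, between 2% and 22%.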

Compound 4, a percentage reported as activity, at one concentration (the size of the read-out at that concentration, not a potency): 7.76%
Compound 4: middle estimate off by 2.2 percentage points, on the high side; low and high end bracket the measured number.
By their numbers in this assay, from the lowest: compounds 2, 4, 1 and 3 (each within the scatter of the next).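

In this assay, placing a (trifluoromethyl)carbonyl group on the aromatic carbon next to the ring nitrogen gives a number 4.4 percentage points lower from compound 3 to compound 4 (within the scatter). The earlier compounds shown here tested a carbonyl group here only as an acetyl, in the other drawn configuration, through a number 1.5 percentage points lower from compound 1 to compound 2 (within the scatter). Both steps lie within the scatter, so this position now tolerates two different carbonyl groups across two configurations without a measurable difference, although the fluorine-bearing group adds six heavy atoms where there was only hydrogen. Nothing measured here explains why the read-out stays the same.

On these data alone, whether an amine or a carboxylic acid on this same carbon would move the number beyond the scatter remains open. A single low concentration also leaves open how these compounds would compare at higher concentrations.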